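Removing a chloro from compound 2: expected lipophilicity of compound 4

The compounds below may be only part of what the source reports. "The series", "measured", "known", "first", "only" and "open" are said of these compounds alone.

Measured so far in a physicochemical assay for lipophilicity; on this read-out lower numbers stand for lower lipophilicity and higher numbers for higher lipophilicity:
Compound 1, `CN1CCN(CCCS(=O)(=O)c2ccc3nc(NC(=O)NC(=O)c4cc(N5CCCC5)c(C#N)cc4Cl)sc3c2)CC1`, gives 2.8.
Compound 2, `CN1CCN(CCCS(=O)(=O)c2ccc3nc(NC(=O)NC(=O)c4cc(-n5cccn5)c(Cl)cc4Cl)sc3c2)CC1`, gives 2.3.
Compound 3, `CC(C)NCCS(=O)(=O)c1ccc2nc(NC(=O)NC(=O)c3ccccc3Cl)sc2c1`, gives 2.3.

Among these three, compound 2 and compound 3 sit level at the digits shown, their gap within the usual scatter, and together they are the lowest pair. Compound 1 stands higher than compound 2 by a margin beyond the scatter. Among the measured compounds shown here, no two of the measured compounds differ in a single place, so no measured step is available to lean on.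

The unmeasured compound 4, `CN1CCN(CCCS(=O)(=O)c2ccc3nc(NC(=O)NC(=O)c4cc(-n5cccn5)ccc4Cl)sc3c2)CC1`, is reached from compound 2 by one change: hydrogen in place of chloro on an aromatic carbon. For the measured compounds named here, nothing among the measured compounds reports the effect of this exact change. Even so, the step from compound 2 to compound 4 in this assay is expected to be downward and beyond the scatter, at about a number 0.60 log units lower from compound 2 to compound 4 (beyond the scatter). Compound 4 is therefore expected to come out at 1.7, most likely between 1.3 and 2.1.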

Compound 4, distribution coefficient: 2
Compound 4: the middle estimate sits 0.30 log units below what was measured, within the range that was stated.
By their numbers in this assay, from the lowest: compounds 4, 2 and 3 (each within the scatter of the next); then compound 1.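

In this assay, putting hydrogen in place of the chloro ortho to the 1H-pyrazol-1-yl group gives a number 0.30 log units lower from compound 2 to compound 4 (within the scatter). Among the compounds shown here, this pair is the first in the set that differs in one place only, so a single change can now be read on its own, and at this position the swap leaves compound 2 and compound 4 unseparated on this read-out. Nothing available explains this result.

Going by these compounds, whether a fluoro, a methyl, a methoxy or an amine on this same carbon would separate from compound 2 or compound 4 remains open. Also open, on these data alone, is whether the same swap would give a similar step on a compound with another side chain or at the chloro meta to this position.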